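A few compounds are considered here, and "the series" means these few. Any claim that something is new, unique, unknown or untested is made for them only; others in the source may bear on it.

Measured so far in a functional assay on HCT-116 cells (Homo sapiens) for cytotoxicity, read by MTT assay, with a stated time of 48 h; on this read-out higher numbers stand for weaker inhibition and lower numbers for stronger inhibition:
- compound 1 `Cc1ccc(-c2c3ccc4ccccc4c3nc3c2c(C)nc2c4ccccc4ccc32)cc1`: 67000 nM
- compound 2 `Cc1nc2c3ccccc3ccc2c2nc3c(ccc4ccccc43)c(-c3cc([N+](=O)[O-])ccc3N)c12`: 6010 nM

Among the measured compounds shown here, compound 2 holds the lowest of the two numbers; its nearest neighbour is compound 1, and the only measured step, an 11-fold lower number from compound 1 to compound 2 (1.05 log units; beyond the scatter), came with 2-amino-5-nitrophenyl in place of 4-methylphenyl. Compound 3 `Cc1nc2c3ccccc3ccc2c2nc3c(ccc4ccccc43)c(-c3cccc([N+](=O)[O-])c3)c12` differs from compound 2 in one place: hydrogen in place of amino on an aromatic carbon, the pendant group thus going from 2-amino-5-nitrophenyl to 3-nitrophenyl. That measured step swapped the whole pendant group, so it speaks only loosely to this smaller trimming. A small step is expected, a 2.0-fold higher number from compound 2 to compound 3 (0.30 log units; within the scatter), toward a somewhat higher number. Compound 3 is expected near 12000 nM, between 4000 nM and 36000 nM.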

Compound 3, half-maximal inhibitory concentration: 13200 nM
Estimate against measurement, compound 3: 1.1-fold (0.04 log units) below; the measured number falls inside the stated range.
By their numbers in this assay, from the lowest: compound 2; then compound 3; then compound 1.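

Within this assay, trimming the amino group para to a nitro group gives a 2.2-fold higher number from compound 2 to compound 3 (0.34 log units; beyond the scatter), a modest step beyond the scatter, so the amino group is not silent at this place. The 3-nitrophenyl pendant without amino still gives a 5.1-fold lower number from compound 1 to compound 3 (0.71 log units; beyond the scatter), so much of the difference from the 4-methylphenyl pendant remains once the amino group is gone. No evidence here gives a reason for either step.

Open, from the compounds shown here alone, is whether the amino step depends on the nitro group, and what a hydroxyl or methoxy group would give in place of amino.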